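The compounds below may be only part of what the source reports. "The series", "measured", "known", "first", "only" and "open" are said of these compounds alone.

Measured so far in an ADME assay on Vero cells (Chlorocebus sabaeus) for cytotoxicity; a higher number here means that more compound is tolerated, a lower number that less compound is tolerated:
- compound 1 `CCCCc1ccc(-c2cc(-c3cn([C@H]4C[C@H](OC(C)=O)[C@@H](COC(C)=O)O4)c(=O)[nH]c3=O)on2)cc1`: 3000 nM
- compound 2 `CC(=O)OC[C@H]1O[C@@H](n2cc(-c3cc(C)no3)c(=O)[nH]c2=O)C[C@@H]1OC(C)=O`: 3000 nM
- compound 3 `CC(=O)OC[C@H]1O[C@@H](n2cc(-c3cc(-c4ccc(C(C)C)cc4)no3)c(=O)[nH]c2=O)C[C@@H]1OC(C)=O`: 3000 nM

Compound 1 stands level with compounds 2 and 3 in this assay; the three values sit at the same figure, so no ordering among them can be drawn.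

The step in view goes from compound 1 to compound 4 `CC(=O)OC[C@H]1O[C@@H](n2cc(-c3cc(-c4ccccc4)no3)c(=O)[nH]c2=O)C[C@@H]1OC(C)=O`. The change is hydrogen in place of butyl on an aromatic carbon, a four-carbon chain leaving an aromatic carbon of a six-membered aromatic ring of carbon only, with nothing but hydrogen entering.

For the measured compounds named here, three measured steps touch the same part of the core. From compound 1 to compound 2 the whole 4-butylphenyl is cut back to methyl: no change at the digits printed from compound 1 to compound 2 (within the scatter). From compound 1 to compound 3 isopropyl stands in for butyl: no change at the digits printed from compound 1 to compound 3 (within the scatter). From compound 2 to compound 3 a 4-isopropylphenyl comes in for methyl: no change at the digits printed from compound 2 to compound 3 (within the scatter). Each is a larger structural change than the loss of a butyl, and none moved this assay beyond the scatter.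

Compound 4 is therefore expected to show no step beyond the scatter in this assay, no change at the digits printed from compound 1 to compound 4 (within the scatter). The estimate for compound 4 is 3000 nM, with a range from 1500 nM to 6000 nM.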

Compound 4, half-maximal cytotoxic concentration: 3000 nM
Estimate against measurement, compound 4: no gap at the digits printed, within the range that was stated.
By their numbers in this assay, from the lowest: compounds 1, 2, 3 and 4 (each within the scatter of the next).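

In this assay, the phenyl carrying no alkyl group reads the same as the alkyl-substituted phenyls: no change at the digits printed from compound 1 to compound 4 (within the scatter), and no change at the digits printed from compound 3 to compound 4 (within the scatter). Against the methyl compound, the bare phenyl also gives no change at the digits printed from compound 2 to compound 4 (within the scatter), so hydrogen now joins butyl and isopropyl on that ring, and the methyl in place of the whole aryl group, at a single figure. No measured evidence bears on why these values coincide.

From the compounds shown here alone, with all four compounds at one value, it remains open whether any change at this position can move this assay beyond the scatter. An amine or a carboxylic acid on the phenyl, or a chain longer than butyl, would put that to the test.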